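Working notes: antiproliferative series, step from compound 1 to compound 4

A few compounds are considered here, and "the series" means these few. Any claim that something is new, unique, unknown or untested is made for them only; others in the source may bear on it.

Measured so far:
compound 1 `CCNC(=O)c1cc(Oc2ccc(NC(=O)c3nn(-c4cccc(F)c4)c(=O)cc3C)cc2)ccn1`: 18900 nM
compound 2 `CCCNC(=O)c1cc(Oc2ccc(NC(=O)c3nn(-c4ccc(C)cc4)c(=O)cc3C)cc2F)ccn1`: 34600 nM
compound 3 `CCCNC(=O)c1cc(Oc2ccc(NC(=O)c3nn(-c4ccc(Br)cc4F)c(=O)cc3C)cc2F)ccn1`: "not active" (no number reported)

In a functional assay on MCF7 cells (Homo sapiens) for antiproliferative activity, read by MTT assay, with a stated time of 72 h (on this read-out lower numbers stand for stronger inhibition and higher numbers for weaker inhibition), compound 1 gives 18900 nM, the lowest of the two numbers recorded. Compound 2 gives 34600 nM in this assay, a gap from compound 1 that lies within the scatter, so no order between the two is claimed. Compound 3 is recorded in this assay as "not active" (no number reported), with no single number. Compound 4 `CCNC(=O)c1cc(Oc2ccc(NC(=O)c3nn(-c4cccc(C(F)(F)F)c4)c(=O)cc3C)cc2)ccn1` has not been measured. It differs from compound 1 in one place: trifluoromethyl in place of fluoro on an aromatic carbon. No step between measured compounds bears on this change, so nothing shown fixes its size; for this assay a step within the scatter, in no set direction, is expected. Compound 4 is therefore expected at 16000 nM, between 5000 nM and 50000 nM, the step of a 1.2-fold lower number from compound 1 to compound 4 (0.07 log units; within the scatter) being estimate only.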

Compound 4, half-maximal inhibitory concentration: 40600 nM
Estimate against measurement, compound 4: 2.5-fold (0.40 log units) below, within the range that was stated.
By their numbers in this assay, from the lowest: compounds 1, 2 and 4 (each within the scatter of the next, the first and the last beyond it).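

In this assay, among these compounds, the change from 3-fluorophenyl to 3-(trifluoromethyl)phenyl gives the first one-place step, read as a 2.1-fold higher number from compound 1 to compound 4 (0.33 log units; beyond the scatter). The substituent at this aromatic carbon therefore registers on the read-out, with trifluoromethyl giving the higher number, though the step is modest and rests on a single pair. No measurement at hand accounts for the step.

On these data alone, whether the same change would give a similar step on other members remains open. So does the reading of an amine, a carboxylic acid or a methoxy group at this carbon.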